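Replacing the formyl group of compound 1

The compounds below may be only part of what the source reports. "The series", "measured", "known", "first", "only" and "open" are said of these compounds alone.

Within the data shown here, in a functional assay on HeLa cells (Homo sapiens) for inhibition (a higher number here means a weaker inhibitor, a lower number a stronger inhibitor), compound 1 `Cc1cn(/C=C/C=O)c(=O)[nH]c1=O` gives 25000 nM, the only exact number so far. Compound 2 `O=C/C=C/n1cc(CO)c(=O)[nH]c1=O` gives > 100000 nM, which is a limit of the assay. Compound 3 `Cc1cn(/C=C/C=N/O)c(=O)[nH]c1=O` keeps the core of compound 1 and changes one group: a group of 3 heavy atoms (1 carbon, 1 nitrogen, 1 oxygen; no ring) in place of a group of 2 heavy atoms (1 carbon, 1 oxygen; no ring), on a double-bonded chain carbon bound to a double-bonded chain carbon. The change lies on a double-bonded chain carbon bound to a double-bonded chain carbon, where formyl leaves.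

Among the measured compounds shown here, only one measured step exists: an at least 4.0-fold higher number from compound 1 to compound 2 (0.60 log units; beyond the scatter). That step lies at another place and retains the formyl group, so it bears only indirectly, as a sign that one small change can raise the number in this series. For the measured compounds named here, a modest move towards a higher number is therefore expected, with no measured precedent at this place. The expected step is a 1.8-fold higher number from compound 1 to compound 3 (0.26 log units; within the scatter). For compound 3 the estimated value is 45000 nM, with an expected range of 15000 nM to 100000 nM.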

Compound 3, half-maximal inhibitory concentration: > 100000 nM
Compound 3: no number, only a limit (the forecaster's own chance of this, stated with the estimate: 35%); middle value at least 2.2-fold (0.34 log units) away from the limit.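

In this assay, putting the group of 3 heavy atoms in place of formyl, on a double-bonded chain carbon bound to a double-bonded chain carbon, gives an at least 4.0-fold higher number from compound 1 to compound 3 (0.60 log units; beyond the scatter). Among these compounds, this is the first measured step at this place, and it shows that the change to the chain end alone, with the rest of compound 1 kept, is enough to move the number beyond the scatter. The value of compound 3 is a limit of the assay, and the full size of the step cannot be read: the limit of > 100000 nM in this assay, at which 2 of the 3 values shown sit.

Whether any replacement of formyl at this place can hold the number of compound 1 stays open, with only this one replacement shown. The data do not separate the group that enters from the formyl that leaves. A carboxylic acid, an amine or a longer chain at this place would test this.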